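Trifluoromethylphenyl in Place of Dichlorophenyl on the Shared Core

The source may report more compounds than this note shows. Statements on the series, on what has been measured and on what is new or still open speak of the compounds shown alone.

Compound 3 `C=CCn1c(=O)/c(=C\c2ccc(Cl)c(Cl)c2)[nH]c(=O)/c1=C\c1ccccc1OC` was tested in a functional assay on NCI-H1975 cells (Homo sapiens) for cytotoxicity, read by CCK-8 assay, with a stated time of 72 h (on this read-out higher numbers stand for weaker inhibition and lower numbers for stronger inhibition), and returned "not active" (no number reported), so no single number stands for it. Compound 1 `COc1ccccc1/C=c1/[nH]c(=O)/c(=C\c2cccc(Cl)c2Cl)[nH]c1=O` likewise gave "not active" (no number reported) in this assay, while compound 2 `C=CCn1c(=O)/c(=C\c2cccc(F)c2)[nH]c(=O)/c1=C\c1ccccc1OC` gave 25600 nM. Compound 3 therefore stands among the entries without a number, one of two such in this small set. Compound 4 `C=CCn1c(=O)/c(=C\c2ccccc2C(F)(F)F)[nH]c(=O)/c1=C\c1ccccc1OC` differs from compound 3 by 2-(trifluoromethyl)phenyl in place of 3,4-dichlorophenyl on a double-bonded chain carbon bound to an aromatic carbon. Within the data shown here, no measured pair in the set isolates this exchange, so nothing in the data fixes the direction or the size of the step. Among the measured compounds shown here, the only compound with a number, compound 2, sits at a weak level, and both chlorine-bearing analogues, compound 1 and compound 3, returned no number at all. On that basis a step no larger than the usual scatter is expected, with a substantial chance that compound 4 again yields no number. Compound 4 is expected to give about 30000 nM in this assay, within a range from 8000 nM to 100000 nM.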

Compound 4, half-maximal inhibitory concentration: 14500 nM
For compound 4 the middle estimate is 2.1-fold (0.32 log units) above the measured one, and the stated range covers the measured number.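

In this assay the exchange of 3-fluorophenyl for 2-(trifluoromethyl)phenyl gives a 1.8-fold lower number from compound 2 to compound 4 (0.25 log units; within the scatter), so these two groups cannot be told apart at this place on the double-bonded chain carbon. From the compounds shown here alone, with compound 4, two aryl groups here now carry a number, whereas 3,4-dichlorophenyl in compound 3 gave "not active" (no number reported), so the step between compound 3 and compound 4 cannot be read and the size of that difference stays unknown. No measured evidence bears on why these groups behave as they do.

The compounds shown leave open what an amine or a carboxylic acid on this phenyl ring would give, or a pyridine ring in its place. They also leave open whether any group here can bring the number far below those of compound 2 and compound 4.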